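Trading a carbamate-bearing side chain for methoxy

The source may hold more compounds than are shown below. What is called first, only, known or untested is meant among the compounds shown, and "the series" means these compounds.

Measured so far:
Compound 1, `CC1=C(N2CC2)C(=O)C(CC(C)OC(N)=O)=C(N2CC2)C1=O`: 5.86
Compound 2, `COCCC1=C(N2CC2)C(=O)C(C)=C(N2CC2)C1=O`: 5.19
Compound 3, `CCC(COC(N)=O)C1=C(N2CC2)C(=O)C(C)=C(N2CC2)C1=O`: 6.03

In a functional assay on L1210 cells (Mus musculus), with a stated time of 1 days (a lower number here means a less potent compound, a higher number a more potent compound, by a factor of ten per unit of this negative logarithm), compound 3 gives 6.03, the highest of the three numbers; compound 1 sits within the scatter of it, so no order between compound 3 and compound 1 can be read, while compound 2 lies clearly lower. Among the compounds with values here, the only step measured so far, a number 0.67 log units lower from compound 1 to compound 2 (beyond the scatter), also swaps a longer side chain carrying a carbamate for a shorter one ending in an ether, and it cost a modest amount.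

Compound 4, `CCC(OC)C1=C(N2CC2)C(=O)C(C)=C(N2CC2)C1=O`, has not yet been measured. It differs from compound 3 by methoxy in place of (carbamoyloxy)methyl on a saturated chain carbon bound to a double-bonded ring carbon and a saturated chain carbon. Within the data shown here, this change is of the same kind as the one from compound 1 to compound 2: the side chain is shortened and its carbamate is gone, leaving a single ether oxygen. Because a number 0.67 log units lower from compound 1 to compound 2 (beyond the scatter) was a loss beyond the scatter, a loss of comparable size is expected for compound 4 in this assay, namely a number 0.63 log units lower from compound 3 to compound 4 (beyond the scatter). Compound 4 is therefore estimated at 5.4, with a range of 4.9 to 5.9.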

Compound 4, logarithm of the reciprocal of the active concentration, log(1/C): 5.26
Estimate against measurement, compound 4: 0.14 log units above; low and high end bracket the measured number.
By their numbers in this assay, from the lowest: compounds 2 and 4 (each within the scatter of the next); then compounds 1 and 3 (each within the scatter of the next).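

Methoxy in place of (carbamoyloxy)methyl on a saturated chain carbon bound to a double-bonded ring carbon and a saturated chain carbon gives a number 0.77 log units lower from compound 3 to compound 4 (beyond the scatter) in this assay, so the loss seen earlier when a carbamate left a side chain now appears a second time, on a differently built chain. With a number 0.07 log units higher from compound 2 to compound 4 (within the scatter) on a double-bonded ring carbon, 1-methoxypropyl and 2-methoxyethyl cannot be ordered, and the two side chains ending in an ether give numbers that this assay does not separate. With a number 0.60 log units lower from compound 1 to compound 4 (beyond the scatter) also beyond the scatter, the carbamate goes with the higher numbers on both chains that carry it, and none of the four compounds goes against this.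

No measurement given here bears on the cause of these steps. Going by these compounds, it stays open whether a hydroxyl or an amine on this saturated chain carbon, or a longer chain ending in a carbamate, would stay near compound 3 at 6.03 or fall towards compound 4 at 5.26 in this series.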